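Methyl additions and the step to compound 4

The source may hold more compounds than are shown below. What is called first, only, known or untested is meant among the compounds shown, and "the series" means these compounds.

compound 1 `COC(=O)CNc1cc(CS(=O)(=O)/C=C/c2c(OC)cc(OC)cc2OC)ccc1OC`: 100 nM
compound 2 `COC(=O)[C@H](C)Nc1cc(CS(=O)(=O)/C=C/c2c(OC)cc(OC)cc2OC)ccc1OC`: 750 nM
compound 3 `COC(=O)C(C)(C)Nc1cc(CS(=O)(=O)/C=C/c2c(OC)cc(OC)cc2OC)ccc1OC`: 2500 nM

All three values come from a functional assay on DU-145 cells (Homo sapiens) for cytotoxicity, read by trypan blue exclusion, with a stated time of 96 h; on this read-out higher numbers stand for weaker inhibition and lower numbers for stronger inhibition. Compound 3 stands highest at 2500 nM, and its steps to both other compounds lie beyond the scatter. The next change, to compound 4 `COc1cc(OC)c(/C=C/S(=O)(=O)Cc2ccc(OC)c(NCCC(=O)O)c2)c(OC)c1`, is 2-carboxyethyl in place of 1-(methoxycarbonyl)-1-methylethyl on a nitrogen on an aromatic ring. Among the measured compounds shown here, three measured steps bear on it: a 7.5-fold higher number from compound 1 to compound 2 (0.88 log units; beyond the scatter), a 3.3-fold higher number from compound 2 to compound 3 (0.52 log units; beyond the scatter) and a 25-fold higher number from compound 1 to compound 3 (1.40 log units; beyond the scatter). Each raised the number as methyl entered. For the measured compounds named here, the 2-carboxyethyl group has no such methyl, but no measured compound carries it, so a lower number in this assay is expected only loosely. The expected step is a 6.3-fold lower number from compound 3 to compound 4 (0.80 log units; beyond the scatter). Compound 4 is estimated at 400 nM, with an expected range of 80 nM to 2000 nM.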

Compound 4, half-maximal inhibitory concentration: 5000 nM
Compound 4: middle estimate off by 13-fold (1.10 log units), on the low side, and the stated range ends below it.
By their numbers in this assay, from the lowest: compound 1; then compound 2; then compounds 3 and 4 (each within the scatter of the next).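

A chain free of added methyl does not by itself keep the number low on this nitrogen: 2-carboxyethyl gives a 50-fold higher number from compound 1 to compound 4 (1.70 log units; beyond the scatter) and a 6.7-fold higher number from compound 2 to compound 4 (0.82 log units; beyond the scatter) as steps beyond or far beyond those of the methyl additions alone. Compared with 1-(methoxycarbonyl)-1-methylethyl, the group shows no readable change (a 2.0-fold higher number from compound 3 to compound 4 (0.30 log units; within the scatter)), so methyl addition is not the only change here that ends at such high numbers. No evidence at hand accounts for this result.

As far as these compounds go, whether the carboxylic acid or the longer chain drives the step stays open, since 2-carboxyethyl differs from (methoxycarbonyl)methyl in both. Carboxymethyl or 2-(methoxycarbonyl)ethyl on the same nitrogen would separate the two.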